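This account rests on a few compounds, and the source may have more. Where it says the series, first, only, none or still open, it means among the compounds named here.

Measured compounds:

compound 1 `COc1cccc(-n2cc3nc(-c4cccnc4C)n(C[C@H]4CCCN(Cc5ccco5)C4)c(=O)c3n2)c1` gives 2.7 nM
compound 2 `CCO[C@@H](C)CN1CCC[C@H](Cn2c(-c3cccnc3C)nc3cn(-c4cccc(OC)c4)nc3c2=O)C1` gives 5 nM
compound 3 `COc1cccc(-n2cc3nc(-c4cccnc4C)n(C[C@H]4CCCN(CC(C)C)C4)c(=O)c3n2)c1` gives 5.7 nM

In an assay on HEK293 cells for displacement of a labelled ligand from growth hormone secretagogue receptor type 1 (Homo sapiens), with a stated time of 60 min (on this read-out lower numbers stand for stronger inhibition and higher numbers for weaker inhibition), compound 3 stands with the highest of the three numbers. Its nearest neighbour is compound 2, and the two lie within the usual scatter of each other; the furthest is compound 1, which lies beyond the scatter, though the gap is modest.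

Compound 4 `COc1cccc(-n2cc3nc(-c4cccnc4C)n(C[C@H]4CCCN(CC5CCO5)C4)c(=O)c3n2)c1` differs from compound 3 in one place: oxetan-2-yl in place of isopropyl on a saturated chain carbon bound to an amine nitrogen in a ring. For the measured compounds named here, two measured steps bear on this kind of change at the same place. The step of a 1.1-fold higher number from compound 2 to compound 3 (0.06 log units; within the scatter) swapped 1-ethoxyethyl for isopropyl and stayed within the scatter. The step of a 2.1-fold higher number from compound 1 to compound 3 (0.32 log units; beyond the scatter) swapped furan-2-yl for isopropyl and gave a modest rise. Going the other way, from isopropyl to a small oxygen-containing ring, a small move toward a lower number, or no move beyond the scatter, is therefore expected.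

Compound 4 is estimated to give 4.5 nM, in the range 2 nM to 10 nM. This estimate means an expected step of a 1.3-fold lower number from compound 3 to compound 4 (0.10 log units; within the scatter).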

Compound 4, half-maximal inhibitory concentration: 23 nM
For compound 4 the middle estimate is 5.1-fold (0.71 log units) below the measured one, and the stated range ends below it.
By their numbers in this assay, from the lowest: compounds 1, 2 and 3 (each within the scatter of the next, the first and the last beyond it); then compound 4.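

In this assay, for the compounds shown here, the oxetan-2-yl group is the first at this place, on a saturated chain carbon bound to an amine nitrogen in a ring, to bring a clear loss: it gives a 4.0-fold higher number from compound 3 to compound 4 (0.61 log units; beyond the scatter) and also a 4.6-fold higher number from compound 2 to compound 4 (0.66 log units; beyond the scatter) as well as an 8.5-fold higher number from compound 1 to compound 4 (0.93 log units; beyond the scatter) when set against the other groups. All three steps lie beyond the scatter, so this place responds to the group it carries more than the earlier, smaller steps showed. An oxygen atom alone does not sort the results, since the 1-ethoxyethyl of compound 2 and the furan-2-yl of compound 1 also hold one and give lower numbers, while the four-membered non-aromatic ring is found only in compound 4.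

No evidence here explains the rise. Going by these compounds, whether the ring itself or the way its oxygen is held matters stays open, as does the outcome for an amine or a longer chain at this place.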